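Working notes: from compound 1 to compound 3

A few compounds are considered here, and "the series" means these few. Any claim that something is new, unique, unknown or untested is made for them only; others in the source may bear on it.

Measured so far:
- compound 1 `NC(=O)c1ccc(-c2cnc(N)c(-c3ccc(C(F)(F)F)cc3)n2)cc1` gives > 90% as a limit
- compound 2 `N#Cc1ccc(-c2cnc(N)c(-c3ccc(N)nc3)n2)cc1` gives > 90% as a limit

In an ADME assay on microsomes from liver (Rattus norvegicus) for metabolic stability, read by LC-MS, using NADPH, with a stated time of 30 min, tested at 0.1 uM, in the presence of a further agent that is not named here (a higher number here means that more of the compound is left, a lower number that less of the compound is left), compound 1 stands at > 90% which is a limit of the assay and not a number. Compound 2 gives > 90% which is likewise a limit. Among the measured compounds shown here, the record so far is thus the limit of > 90% in this assay, at which 2 of the 2 values shown sit, and it holds no measured step between compounds.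

Compound 3 `Nc1ncc(-c2ccc(C(=O)N3CC[C@H](O)C3)cc2)nc1-c1ccc(C(F)(F)F)cc1` keeps the core of compound 1 and differs by 3-hydroxypyrrolidin-1-yl in place of amino on a carbonyl carbon. For the measured compounds named here, no measured pair shows the effect of this change, so the expectation is tentative. The estimated move is a number at least 8 percentage points lower from compound 1 to compound 3 (that floor lies within the scatter) in this assay and this expected fall is modest, possibly no larger than the usual scatter. Compound 3 is expected at 82% with an estimated range from 60% to 97% and a report as a limit also remains possible.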

Compound 3, percent of the compound remaining: > 90%
Compound 3 gave a limit, no number; the forecaster's own chance of this, stated with the estimate: 35%; middle value at least 8 percentage points away from the limit.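

No step from compound 1 to compound 3 can be read in this assay, because both are reported only as a limit and not as a number: the limit of > 90% in this assay, at which 3 of the 3 values shown sit.

The compounds shown leave open whether 3-hydroxypyrrolidin-1-yl in place of amino on a carbonyl carbon changes the result in this assay at all, and by how much.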